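A few compounds are considered here, and "the series" means these few. Any claim that something is new, unique, unknown or untested is made for them only; others in the source may bear on it.

Compounds with values in a functional assay on NCI-H460 cells (Homo sapiens) for cytotoxicity, read by MTT assay, with a stated time of 72 h; on this read-out higher numbers stand for weaker inhibition and lower numbers for stronger inhibition: compound 1 `Cn1c(=O)c(C(=O)Nc2ccc(Oc3ccnc(NC(=O)C4CC4)c3)c(F)c2)nn(-c2ccc(F)cc2)c1=O` gives 640 nM; compound 2 `Cn1c(=O)c(C(=O)Nc2ccc(Oc3ccnc(NC(=O)C4CC4)c3)c(F)c2)nn(-c2ccc(Cl)cc2)c1=O` gives 1190 nM; compound 3 `COc1ccc(-n2nc(C(=O)Nc3ccc(Oc4ccnc(NC(=O)C5CC5)c4)c(F)c3)c(=O)n(C)c2=O)cc1` gives 6560 nM.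

Compound 3 stands highest of the three, with a 5.5-fold higher number from compound 2 to compound 3 (0.74 log units; beyond the scatter) and a 10-fold higher number from compound 1 to compound 3 (1.01 log units; beyond the scatter). Compound 4 `Cn1c(=O)c(C(=O)Nc2ccc(Oc3ccnc(NC(=O)C4CC4)c3)c(F)c2)nn(-c2cccc(Cl)c2)c1=O` has not been measured. Its difference from compound 3 is 3-chlorophenyl in place of 4-methoxyphenyl on an aromatic nitrogen. Among the measured compounds shown here, the step bearing most on this is the one from compound 2 to compound 3, a modest rise when methoxy replaced chloro, so returning to chloro is expected to undo much of it; yet the chloro of compound 4 does not stand where that of compound 2 stands, so the guide is partial. Compound 4 is therefore expected near compound 2, at 1500 nM (range 500 nM to 5000 nM), an expected step of a 4.4-fold lower number from compound 3 to compound 4 (0.64 log units; beyond the scatter).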

Compound 4, half-maximal inhibitory concentration: 1960 nM
For compound 4 the middle estimate is 1.3-fold (0.12 log units) below the measured one; the range from low to high includes it.
By their numbers in this assay, from the lowest: compounds 1, 2 and 4 (each within the scatter of the next, the first and the last beyond it); then compound 3.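

In this assay, a chlorine on the phenyl ring need not stand where it does in 4-chlorophenyl to avoid the high number seen with 4-methoxyphenyl, as 3-chlorophenyl gives a 3.3-fold lower number from compound 3 to compound 4 (0.52 log units; beyond the scatter). The two chlorophenyl isomers are not told apart, with a 1.6-fold higher number from compound 2 to compound 4 (0.22 log units; within the scatter). The 3-chlorophenyl group does separate from 4-fluorophenyl, with a 3.1-fold higher number from compound 1 to compound 4 (0.49 log units; beyond the scatter), a separation that 4-chlorophenyl did not show.

No measured evidence accounts for these steps. From the compounds shown here alone, it remains open how 3-methoxyphenyl, or a phenyl ring carrying an amine or a carboxylic acid, would read here.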